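Amide to amine on the piperidine nitrogen of compound 2

The source may hold more compounds than are shown below. What is called first, only, known or untested is meant among the compounds shown, and "the series" means these compounds.

Measured so far in an in vitro functional assay on HEK ts201 cells for antagonist activity at Neuronal acetylcholine receptor; alpha4/beta2 (Homo sapiens), read by fluorescence and calcium flux; on this read-out lower numbers stand for stronger inhibition and higher numbers for weaker inhibition:
compound 1, `O=C(NCc1cccc2ccccc12)c1ccccc1-c1ccccc1`, gives 13900 nM;
compound 2, `O=C(OC1CCCN(C(=O)CCc2ccccc2)C1)c1ccccc1-c1ccccc1`, gives 4300 nM;
compound 3, `C[C@@H]1CC(=O)N(c2ccccc2C(=O)OC[C@@H]2CCCN(CCCc3ccccc3)C2)C1=O`, gives 8910 nM.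

Compound 2 has the lowest of the three numbers; compound 3 is nearest with a higher number beyond the scatter, and compound 1 is furthest, also beyond the scatter. Compound 4, `O=C(OC1CCCN(CCCc2ccccc2)C1)c1ccccc1-c1ccccc1`, has not yet been measured. It differs from compound 2 in one place: 3-phenylpropyl in place of phenethylcarbonyl on an amine nitrogen in a ring. Among the measured compounds shown here, no step between measured compounds covers this change, so the expectation rests on compound 2 alone. A small step toward stronger inhibition is expected in this assay, likely not far beyond the scatter, since compound 3 carries the same 3-phenylpropyl group and gives 8910 nM. Compound 4 is estimated at 2800 nM, within 900 nM to 9000 nM, a step of a 1.5-fold lower number from compound 2 to compound 4 (0.19 log units; within the scatter).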

Compound 4, half-maximal inhibitory concentration: 6500 nM
Compound 4: the middle estimate sits 2.3-fold (0.37 log units) below what was measured, and the stated range covers the measured number.
By their numbers in this assay, from the lowest: compounds 2, 4, 3 and 1 (each within the scatter of the next, the first and the last beyond it).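

In this assay the exchange of phenethylcarbonyl for 3-phenylpropyl on the amine nitrogen in the ring gives a 1.5-fold higher number from compound 2 to compound 4 (0.18 log units; within the scatter) and so does not separate the two groups. At this position the assay tolerates losing the carbonyl, and the amide and amine forms read alike. Nothing shown gives a reason for this.

On these data alone, whether a benzyl group or a longer chain on this nitrogen would read any differently stays open. So does whether a basic amine replaced by a sulfonamide here would match either group.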